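The source may report more compounds than this note shows. Statements on the series, on what has been measured and on what is new or still open speak of the compounds shown alone.

In a functional assay on PC-3 cells (Homo sapiens) for inhibition, read by sulforhodamine B assay (a lower number here means a stronger inhibitor of growth, a higher number a weaker inhibitor of growth), compound 1 `Oc1cccc2[nH]c(-c3ccc(-c4ccc(-c5ccc(OC(F)(F)F)cc5)cc4)cc3)nc12` gives 7410 nM and compound 2 `CN(C)c1ccc(-c2ccc(-c3ccc(-c4nc5c(O)cccc5[nH]4)cc3)cc2)cc1` gives 8420 nM, so compound 2 stands level with compound 1, within the scatter. Compound 3 `Oc1cccc2[nH]c(-c3ccc(-c4ccc(-c5cccc(Cl)c5)cc4)cc3)nc12` carries 3-chlorophenyl in place of 4-(dimethylamino)phenyl on an aromatic carbon. Among the compounds with values here, the one measured step, a 1.1-fold higher number from compound 1 to compound 2 (0.06 log units; within the scatter), exchanged trifluoromethoxy for dimethylamino, and it lies within the scatter. Within the data shown here, it bears only loosely on this change, as no compound with a chlorine has been measured. On that evidence, no step beyond the scatter is expected, and the estimated step is a 1.2-fold lower number from compound 2 to compound 3 (0.08 log units; within the scatter). Compound 3 is expected at 7000 nM, with an estimated range of 2800 nM to 18000 nM.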

Compound 3, concentration for 50% growth inhibition: 2560 nM
The estimate for compound 3 lay 2.7-fold (0.44 log units) above the measured number; measured number outside the range, below it.
By their numbers in this assay, from the lowest: compound 3; then compounds 1 and 2 (each within the scatter of the next).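

In this assay the position proves able to shift the number beyond the scatter, a modest move seen in both new steps (a 3.3-fold lower number from compound 2 to compound 3 (0.52 log units; beyond the scatter)) and (a 2.9-fold lower number from compound 1 to compound 3 (0.46 log units; beyond the scatter)). Where trifluoromethoxy and dimethylamino stood level, 3-chlorophenyl separates from both 4-substituted phenyl groups. The compounds shown leave open whether this shift follows the chlorine or its place on the ring, a question that 4-chlorophenyl would separate, and whether 3-bromophenyl would behave alike. Nothing available accounts for the shift.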